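Cytotoxicity of an ester and its primary amide

A few compounds are considered here, and "the series" means these few. Any claim that something is new, unique, unknown or untested is made for them only; others in the source may bear on it.

Measured compounds in an ADME assay on HS27 cells (Homo sapiens) for cytotoxicity, read by MTT assay; on this read-out higher numbers stand for weaker inhibition and lower numbers for stronger inhibition:
Compound 1 `O=C(Nc1ccc(-n2ccc3nc(C(=O)NCc4ccccc4)ccc32)cc1)Nc1cccc(Cl)c1Cl` gives > 10000 nM, a limit of the assay.
Compound 2 `COC(=O)c1ccc2c(ccn2-c2ccc(NC(=O)Nc3cccc(Cl)c3Cl)cc2)n1` gives > 10000 nM, a limit of the assay.

Compound 2 stands only at a limit in this assay, and that limit is where the other measured value sits as well (the limit of > 10000 nM in this assay, at which 2 of the 2 values shown sit). Among the compounds with values here, the one measured step, a step that the two limits leave unreadable from compound 1 to compound 2, joins two limits, so its size cannot be read. Compound 3 `NC(=O)c1ccc2c(ccn2-c2ccc(NC(=O)Nc3cccc(Cl)c3Cl)cc2)n1` differs from compound 2 in one place: amino in place of methoxy on a carbonyl carbon. Within the data shown here, no measured step bears on this change with a readable size; the step from compound 1 to compound 2 also exchanged the group on that carbonyl carbon, but both ends of it are limits. With every measured value at the limit, there is no ground to expect a shift beyond the scatter, and the most likely outcome is that compound 3 again reports only a limit. The step that the limit leaves unreadable from compound 2 to compound 3 is therefore expected to be none. Compound 3 is estimated at 20000 nM, with a range from 8000 nM to 60000 nM.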

Compound 3, half-maximal inhibitory concentration: 9800 nM
Compound 3: the middle estimate sits 2.0-fold (0.31 log units) above what was measured, and the stated range covers the measured number.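

In this assay, within the data shown here, compound 3 gives 9800 nM, a true number and the first value here that is not a limit of the assay. Amino in place of methoxy on a carbonyl carbon gives an at least 1.0-fold lower number from compound 2 to compound 3 (0.00 log units; that floor lies within the scatter), while hydrogen in place of benzyl on an amide-type nitrogen gives an at least 1.0-fold lower number from compound 1 to compound 3 (0.00 log units; that floor lies within the scatter). Each step is only a floor, so the carbamoyl compound gives this position a readable end point but no demonstrated change in size, and the comparison stays bounded on one side: the limit of > 10000 nM in this assay, at which 2 of the 3 values shown sit.

The compounds shown leave open whether a carboxylic acid or a methylamide on the same carbonyl carbon would also give a number rather than a limit. They also leave open how large the real gaps are between compound 3 and the two compounds that report only a limit, and so whether either change does anything beyond the scatter.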